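Phenyl in place of cyclohexyl: working notes on the series

This account rests on a few compounds, and the source may have more. Where it says the series, first, only, none or still open, it means among the compounds named here.

Measured so far in a functional assay on MCF7 cells (Homo sapiens) for inhibition, read by sulforhodamine B assay, with a stated time of 48 h (a lower number here means a stronger inhibitor of growth, a higher number a weaker inhibitor of growth), are two compounds:
compound 1 `c1cc(OC2CCCC2)ccc1NC1=NCCO1` gives 23100 nM
compound 2 `c1cc(OC2CCCCC2)ccc1NC1=NCCO1` gives 19100 nM

Compound 2, at 19100 nM, cannot be separated from compound 1, at 23100 nM, since the two values lie within the scatter of each other. The next structure is compound 3 `c1ccc(Oc2ccc(NC3=NCCO3)cc2)cc1`, which has phenyl in place of cyclohexyl on an oxygen on an aromatic ring. Among the compounds with values here, one measured step bears on this change, namely a 1.2-fold lower number from compound 1 to compound 2 (0.08 log units; within the scatter), which has cyclohexyl in place of cyclopentyl at the same place and stays within the scatter. That step only exchanges one non-aromatic carbon ring for another. Within the data shown here, no measured compound carries an aromatic ring at this place, so the guidance is thin and the range is kept wide. Among the measured compounds shown here, with a 1.2-fold lower number from compound 1 to compound 2 (0.08 log units; within the scatter) as the sole guide, no step beyond the scatter is expected in this assay, and no direction is favoured. The estimated step is a 1.1-fold lower number from compound 2 to compound 3 (0.03 log units; within the scatter), which is small. The expected value for compound 3 is 18000 nM, with an estimated range from 7000 nM to 45000 nM.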

Compound 3, concentration for 50% growth inhibition: 3500 nM
Compound 3: the middle estimate sits 5.1-fold (0.71 log units) above what was measured, and the stated range ends above it.
By their numbers in this assay, from the lowest: compound 3; then compounds 2 and 1 (each within the scatter of the next).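

In this assay, the group on this oxygen turns out to matter: a 5.5-fold lower number from compound 2 to compound 3 (0.74 log units; beyond the scatter) and a 6.6-fold lower number from compound 1 to compound 3 (0.82 log units; beyond the scatter), whereas the exchange between the two non-aromatic carbon rings gave only a 1.2-fold lower number from compound 1 to compound 2 (0.08 log units; within the scatter). Cyclohexyl and phenyl have the same counts of heavy atoms, hydrogen-bond donors and hydrogen-bond acceptors, and neither carries a net charge, so the difference recorded between compound 2 and compound 3 is a non-aromatic versus an aromatic six-membered carbon ring. Nothing on hand accounts for the lower number of compound 3, so the step stands as an observation without an explanation.

Within the data shown here, compound 3 is the only compound here with an aromatic ring at this place, so it remains open whether the lower number is particular to unsubstituted phenyl or extends to a pyridine ring, or to a phenyl carrying a chlorine, a methoxy group or a carboxylic acid. The compounds shown also leave open whether the same step appears with the core of compound 1 altered, since all three share that core and differ only in the group on the oxygen.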